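Swapping a Nitrobenzyl Ether for a Methoxybenzyl Ether

A few compounds are considered here, and "the series" means these few. Any claim that something is new, unique, unknown or untested is made for them only; others in the source may bear on it.

Of the compounds shown here, three sharing one core have been tested in a functional assay on PC-3 cells (Homo sapiens) for cytotoxicity, read by sulforhodamine B assay; on this read-out higher numbers stand for weaker inhibition of growth and lower numbers for stronger inhibition of growth. Compound 1 `COc1cccc(OC)c1OCCNCCOc1ccccc1OCc1ccccc1` gives 76900 nM. Compound 2 `COc1cccc(OC)c1OCCNCCOc1ccccc1OCc1ccccc1Cl` gives 17800 nM, and compound 3 `COc1cccc(OC)c1OCCNCCOc1ccccc1OCc1cccc([N+](=O)[O-])c1` gives 38900 nM. On these numbers compound 3 stands second highest of the three, close to compound 1 and furthest from compound 2. Compound 4 `COc1ccccc1COc1ccccc1OCCNCCOc1c(OC)cccc1OC` differs from compound 3 by 2-methoxyphenyl in place of 3-nitrophenyl on a saturated chain carbon bound to an oxygen on an aromatic ring. The measured steps that bear on this change are a 4.3-fold lower number from compound 1 to compound 2 (0.64 log units; beyond the scatter) and a 2.2-fold higher number from compound 2 to compound 3 (0.34 log units; beyond the scatter), together with a 2.0-fold lower number from compound 1 to compound 3 (0.30 log units; within the scatter); none of them involves a methoxy group. A step of modest size towards lower numbers is therefore expected, and for compound 4 in this assay a value of 30000 nM is estimated, between 10000 nM and 90000 nM, which would mean an expected step of a 1.3-fold lower number from compound 3 to compound 4 (0.11 log units; within the scatter).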

Compound 4, concentration for total growth inhibition: 30200 nM
Estimate against measurement, compound 4: 1.0-fold (0.00 log units) below, and the stated range covers the measured number.
By their numbers in this assay, from the lowest: compounds 2, 4, 3 and 1 (each within the scatter of the next, the first and the last beyond it).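

Methoxy joins chloro as a second group on this benzyl ring whose step from plain hydrogen lies beyond the scatter (a 2.5-fold lower number from compound 1 to compound 4 (0.41 log units; beyond the scatter)). Compound 4 cannot be separated from the nitro compound (a 1.3-fold lower number from compound 3 to compound 4 (0.11 log units; within the scatter)) or from the chloro compound (a 1.7-fold higher number from compound 2 to compound 4 (0.23 log units; within the scatter)), even though those two differ from each other beyond the scatter. No measurement at hand explains these steps.

On these data alone, each group appears at a single ring position, so the effect of moving it remains unknown. As far as these compounds go, how an amine or a carboxylic acid would behave on this ring also stays open.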